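A few compounds are considered here, and "the series" means these few. Any claim that something is new, unique, unknown or untested is made for them only; others in the source may bear on it.

Compound 3 `O=C(C1CCCCO1)N1CCc2nc(C#Cc3ccccc3)sc2C1` stands at the edge of what an assay on HEK293 cells for negative allosteric modulation of metabotropic glutamate receptor 5 (Homo sapiens), read by FLIPR, with a stated time of 1 h (on this read-out lower numbers stand for stronger inhibition and higher numbers for weaker inhibition), can report: compound 3 gives > 10000 nM, which is a limit rather than a number. Compound 2 `O=C(C1CCC(F)(F)CC1)N1CCc2nc(C#Cc3ccccc3)sc2C1` likewise gives only the limit > 10000 nM in this assay. Compound 1 `CCC(=O)N1CCc2nc(C#Cc3ccccc3)sc2C1` gives 38 nM. Both moves from ethyl to a larger saturated ring on the carbonyl carbon point the same way: an at least 260-fold higher number from compound 1 to compound 2 (2.42 log units; beyond the scatter) and an at least 260-fold higher number from compound 1 to compound 3 (2.42 log units; beyond the scatter), while a step that the two limits leave unreadable from compound 2 to compound 3. Compound 4 `O=C(c1cccc(Cl)c1)N1CCc2nc(C#Cc3ccccc3)sc2C1` carries 3-chlorophenyl in place of oxan-2-yl on a carbonyl carbon, an aromatic ring where a saturated one stood. Going by the values given here, no measured step covers an aromatic group here, so the expectation is uncertain, and because the limit of > 10000 nM in this assay, at which 2 of the 3 values shown sit, compound 3 itself may lie far beyond its limit. The step is expected to be an at least 25-fold lower number from compound 3 to compound 4 (1.39 log units; beyond the scatter). Compound 4 is therefore estimated at 400 nM, ranging from 30 nM to 6000 nM.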

Compound 4, half-maximal inhibitory concentration: > 10000 nM
Compound 4 was reported as a limit (the forecaster's own chance of this, stated with the estimate: 25%); middle value at least 25-fold (1.39 log units) away from the limit.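

Compound 4 shows that an aromatic ring fares no better at this position than the saturated rings, and its value is a limit, not a number. Putting 3-chlorophenyl in place of ethyl on the carbonyl carbon gives an at least 260-fold higher number from compound 1 to compound 4 (2.42 log units; beyond the scatter). The steps among compound 2, compound 3 and compound 4 cannot be read, because all three end at the same limit: the limit of > 10000 nM in this assay, at which 3 of the 4 values shown sit.

Open, from the compounds shown here alone, is how smaller groups, such as a cyclopropyl ring or a propyl chain, would read on this carbonyl carbon. Also open, going by these compounds, is whether an unsubstituted phenyl would behave like 3-chlorophenyl.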